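The source may hold more compounds than are shown below. What is called first, only, known or untested is meant among the compounds shown, and "the series" means these compounds.

Working notes on the series. Compound 1 `CCCC(=O)N1CC2CC(C1)N2`, the propyl amide, gives 350 nM in an assay on CHO cells for displacement of a labelled ligand from Neuronal acetylcholine receptor; alpha3/alpha6/beta2/beta3 (Homo sapiens), read by scintillation counting; on this read-out lower numbers stand for stronger inhibition and higher numbers for weaker inhibition. Compound 2 `O=C([C@H]1C[C@H]1F)N1CC2CC(C1)N2`, carrying the 2-fluorocyclopropyl group, gives 27 nM; compound 3 `C[C@@H]1C[C@@H]1C(=O)N1CC2CC(C1)N2`, carrying a methyl in place of that fluoro, gives 92 nM. Within these three numbers compound 3 stands second highest: a 3.8-fold lower number from compound 1 to compound 3 (0.58 log units; beyond the scatter), while a 3.4-fold higher number from compound 2 to compound 3 (0.53 log units; beyond the scatter). Both steps on the carbonyl substituent are modest.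

Compound 4 `C[C@H]1C[C@@H]1C(=O)N1CC2CC(C1)N2` is the next member. Against compound 3 the change is the two compounds have the same atoms and bonds; at least one stereo element is drawn with a configuration in one of them and without one in the other: 1 of 4 stereo elements differ; a stereocentre at a saturated ring carbon is drawn R in compound 3 and S in compound 4. For the measured compounds named here, no measured step in the set changes only a stereocentre, so no direct precedent exists; the two steps that do touch the cyclopropane substituent, a 3.8-fold lower number from compound 1 to compound 3 (0.58 log units; beyond the scatter) and a 3.4-fold higher number from compound 2 to compound 3 (0.53 log units; beyond the scatter), were both modest, which suggests that changes at this ring tend to move the number by modest amounts in this assay. The direction of a stereo flip cannot be read from the data. A step expected for compound 4, from compound 3, is therefore near zero with a wide spread: a 1.3-fold higher number from compound 3 to compound 4 (0.12 log units; within the scatter). Compound 4 is estimated at 120 nM, range 30 nM to 500 nM.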

Compound 4, inhibition constant: 310 nM
Estimate against measurement, compound 4: 2.6-fold (0.41 log units) below; measured number inside the range.
By their numbers in this assay, from the lowest: compound 2; then compound 3; then compounds 4 and 1 (each within the scatter of the next).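

With the same atoms and bonds, the stereocentre at a saturated ring carbon alone gives a 3.4-fold higher number from compound 3 to compound 4 (0.53 log units; beyond the scatter), a step as large as those that earlier exchanged groups at this place. The 2-methylcyclopropyl group in this drawing shows no separation from the propyl group, a 1.1-fold lower number from compound 1 to compound 4 (0.05 log units; within the scatter), while the distance from the 2-fluorocyclopropyl group is an 11-fold higher number from compound 2 to compound 4 (1.06 log units; beyond the scatter), so the gain seen with compound 3 belongs to one drawing of the group and not to the cyclopropane ring as such. The reading as a stereo effect carries one limit: the fact that one of compounds 3 and 4 is drawn with a defined configuration and the other without, at the place where they differ.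

Going by these compounds, whether the 2-fluorocyclopropyl group responds to the same change of configuration stays open. So does the response of larger groups at this ring carbon, such as ethyl or hydroxymethyl, in either configuration.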